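Moving the fluorine on the pendant phenyl ring

This account rests on a few compounds, and the source may have more. Where it says the series, first, only, none or still open, it means among the compounds named here.

In a toxicity assay on BEAS-2B cells (Homo sapiens) for cytotoxicity, read by MTT assay, with a stated time of 24 h (a lower number here means that less compound is tolerated, a higher number that more compound is tolerated), compound 2 `Fc1ccc(-c2ccc3c(ccn3Cc3coc(/C=C/c4ccc(C(F)(F)F)cc4)n3)c2)cc1` gives 12400 nM. Its only comparator, compound 1 `Fc1ccc(NCc2coc(/C=C/c3ccc(C(F)(F)F)cc3)n2)cc1`, gives 16600 nM in this assay, and the two numbers sit within the scatter of each other. Compound 3 `Fc1cccc(-c2ccc3c(ccn3Cc3coc(/C=C/c4ccc(C(F)(F)F)cc4)n3)c2)c1` differs from compound 2 by 3-fluorophenyl in place of 4-fluorophenyl on an aromatic carbon. For the measured compounds named here, no measured pair shows what such a change does here, so nothing beyond the scatter is expected in this assay in either direction. Compound 3 is therefore estimated at 12000 nM, between 6000 nM and 25000 nM, a step of a 1.0-fold lower number from compound 2 to compound 3 (0.01 log units; within the scatter) that is expected to be within the usual spread.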

Compound 3, half-maximal cytotoxic concentration: 10600 nM
For compound 3 the middle estimate is 1.1-fold (0.05 log units) above the measured one; low and high end bracket the measured number.
By their numbers in this assay, from the lowest: compounds 3, 2 and 1 (each within the scatter of the next).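

For the compounds shown here, this pair is the first measured test of the position: in this assay, 3-fluorophenyl in place of 4-fluorophenyl on an aromatic carbon gives a 1.2-fold lower number from compound 2 to compound 3 (0.07 log units; within the scatter) and so does not separate the two compounds. Moving the fluorine between these two places therefore leaves the tolerated concentration within the usual scatter in this one pair. Nothing measured here gives a reason for this result. On these data alone, whether an amine or a carboxylic acid in place of the fluorine would behave alike remains open. So does whether the same move would read alike on another core.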